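The compounds below may be only part of what the source reports. "The series", "measured", "known", "first", "only" and "open" are said of these compounds alone.

Working notes on the series, all read in a functional assay on CCRF-CEM cells (Homo sapiens), read by MTT assay, with a stated time of 72 h; a higher number here means a weaker inhibitor, a lower number a stronger inhibitor. Compound 3 (`CN(C)c1ncnc2c1c(-c1ccoc1)cn2[C@@H]1O[C@H](CO)[C@@H](O)[C@H]1O`) gives 13300 nM, compound 2 (`CSc1ncnc2c1c(-c1ccoc1)cn2[C@@H]1O[C@H](CO)[C@@H](O)[C@H]1O`) gives 14200 nM, and compound 1 (`COc1ncnc2c1c(-c1cc3ccccc3o1)cn2[C@@H]1O[C@H](CO)[C@@H](O)[C@H]1O`) gives 5370 nM. Compound 3 thus stands level with compound 2 at the upper end of the three numbers, while compound 1 lies lower by a margin beyond the scatter.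

The next step leads to compound 4 (`CN(C)c1ncnc2c1c(-c1cc3ccccc3o1)cn2[C@@H]1O[C@H](CO)[C@@H](O)[C@H]1O`), with 1-benzofuran-2-yl in place of furan-3-yl on an aromatic carbon.

Among the compounds with values here, no measured step makes this exchange directly. Within the data shown here, the one measured step, a 1.1-fold lower number from compound 2 to compound 3 (0.03 log units; within the scatter), puts dimethylamino in place of methylsulfanyl with both compounds carrying furan-3-yl, and it stays within the scatter. Compound 1 already carries 1-benzofuran-2-yl, but with methoxy where compound 3 has dimethylamino, so its gap to compound 3 mixes two changes and is only indirect evidence. The exchange of methoxy for dimethylamino has not been measured. If it proves as small as the measured step, compound 4 should land near compound 1 at 5370 nM.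

The expected move, toward a lower number and modestly beyond the scatter, is a 2.2-fold lower number from compound 3 to compound 4 (0.35 log units; beyond the scatter). For compound 4 the estimate is 6000 nM, with an expected range of 2000 nM to 18000 nM.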

Compound 4, half-maximal inhibitory concentration: > 20000 nM
Compound 4: a limit, no number; the forecaster's own chance of this, stated with the estimate: 10%; middle value at least 3.3-fold (0.52 log units) away from the limit.
By their numbers in this assay, from the lowest: compound 1; then compounds 3 and 2 (each within the scatter of the next). At a limit, above all of these: compound 4.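

In this assay, compound 4 stands at a limit of the assay and not at a number: the limit of > 20000 nM in this assay, at which 1 of the 4 values shown sits.

With dimethylamino held constant, the exchange of furan-3-yl for 1-benzofuran-2-yl at this position brings no lowering of the number, and the step reads an at least 1.5-fold higher number from compound 3 to compound 4 (0.17 log units; that floor lies within the scatter), so its true size stays undetermined. Within the data shown here, with 1-benzofuran-2-yl held constant, the step reads an at least 3.7-fold higher number from compound 1 to compound 4 (0.57 log units; beyond the scatter), which shows for the first time that the exchange of methoxy for dimethylamino on the aromatic carbon can matter, whereas the exchange of methylsulfanyl for dimethylamino with furan-3-yl in place gave a 1.1-fold lower number from compound 2 to compound 3 (0.03 log units; within the scatter).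

The compounds shown leave open whether the large gap belongs to dimethylamino alone or to its pairing with 1-benzofuran-2-yl, as no methoxy compound carrying furan-3-yl stands among them. Also open, as far as these compounds go, is how a primary amino group or a methylamino group on the same aromatic carbon would read with 1-benzofuran-2-yl, and whether a plain phenyl ring in place of either furan-containing group would follow compound 1 or compound 4.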